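This account rests on a few compounds, and the source may have more. Where it says the series, first, only, none or still open, it means among the compounds named here.

Measured in a functional assay on the whole organism (strain CD1) with Mus musculus as the target, in the maximal electroshock model, with a stated time of 4 h; on this read-out lower numbers stand for an effect already at smaller amounts and higher numbers for an effect only at larger amounts of compound: compound 1 `CC1CC(=O)N(CC(=O)N2CCN(c3cccc(Cl)c3)CC2)C1=O` gives 300 mg/kg; compound 2 `CCC1(C)CC(=O)N(CC(=O)N2CCN(c3cccc(C(F)(F)F)c3)CC2)C1=O` gives 100 mg/kg; compound 3 `CC1CC(=O)N(CC(=O)N2CCN(c3ccccc3F)CC2)C1=O` gives 300 mg/kg.

Compound 2 stands at the lowest of the three numbers; compound 1 and compound 3 each sit at a higher dose in this assay, and both gaps lie beyond the scatter. Among the compounds with values here, the only single-place step measured, no change at the digits printed from compound 1 to compound 3 (within the scatter), exchanges the aryl group on the amine nitrogen in the ring and leaves the dose unchanged; it does not touch the five-membered ring. Compound 4 `CC1CC(=O)N(CC(=O)N2CCN(c3cccc(C(F)(F)F)c3)CC2)C1=O` differs from compound 2 in one place: hydrogen in place of ethyl on a saturated ring carbon. Within the data shown here, no measured step alters a group on that saturated ring carbon. What remains as a guide is that compound 1 and compound 3, which carry a hydrogen at that place, both show a higher dose than compound 2, though each also carries a different aryl group. The dose for compound 4 is therefore expected to rise modestly, a 2.0-fold higher number from compound 2 to compound 4 (0.30 log units; within the scatter), with wide uncertainty. Compound 4 is estimated at 200 mg/kg, in the range 100 mg/kg to 400 mg/kg.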

Compound 4, minimum effective dose: 100 mg/kg
The estimate for compound 4 lay 2.0-fold (0.30 log units) above the measured number, within the range that was stated.
By their numbers in this assay, from the lowest: compounds 2 and 4 (each within the scatter of the next); then compounds 1 and 3 (each within the scatter of the next).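

In this assay, the saturated ring carbon two ring bonds from the ring nitrogen gives up its ethyl without a measurable cost, with no change at the digits printed from compound 2 to compound 4 (within the scatter) when hydrogen enters, so ethyl at this place is not needed for the dose seen in this pair. The aromatic carbon now stands out as the place that moves the number, with a 3.0-fold lower number from compound 1 to compound 4 (0.48 log units; beyond the scatter) when trifluoromethyl replaces chloro on the shared core. No supporting evidence is available to explain either result.

On these data alone, it remains open whether a longer chain, a phenyl or a hydroxyl on the saturated ring carbon would leave the dose where it stands. As far as these compounds go, it is also open how a methoxy or a nitrile on the aromatic carbon would compare with trifluoromethyl and chloro.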